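This account rests on a few compounds, and the source may have more. Where it says the series, first, only, none or still open, it means among the compounds named here.

Working notes on the series. In an ADME assay on HepG2 cells (Homo sapiens) for cytotoxicity, with a stated time of 72 h (on this read-out lower numbers stand for an effect already at smaller amounts and higher numbers for an effect only at larger amounts of compound), compound 1 (`Cc1ccc(-c2nc3ccccc3s2)cc1NC(=O)c1cc([N+](=O)[O-])c(N(C)C)cc1Cl`) gives > 25000 nM, which is a limit of the assay and not a number. Compound 2 (`O=C(Nc1ccc(O)c(-c2nc3ccccc3s2)c1)c1cc([N+](=O)[O-])ccc1Cl`) gives > 25000 nM, again a limit and not a number. For the measured compounds named here, the position of compound 1 is therefore known only as a limit, with no numerical value to anchor it, and the series so far shows (the limit of > 25000 nM in this assay, at which 2 of the 2 values shown sit).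

The step under consideration leads to compound 3 (`Cc1ccc(-c2nc3ccccc3s2)cc1NC(=O)c1cc([N+](=O)[O-])c(N2CCCCC2)cc1Cl`), with piperidin-1-yl in place of dimethylamino on an aromatic carbon. Going by the values given here, no measured pair sizes this change. In this assay the expected change, a step that the limit leaves unreadable from compound 1 to compound 3, is none beyond the usual scatter, with no direction favoured. This expectation rests on compound 1 at > 25000 nM, a limit. A further limit is the likeliest reading for the new compound. Compound 3 is estimated at 28000 nM, with an expected range from 12000 nM to 60000 nM.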

Compound 3, half-maximal effective concentration: > 25000 nM
Compound 3: only a limit was reported (the forecaster's own chance of this, stated with the estimate: 70%); the middle value lies beyond the limit too.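

No step can be read from compound 1 to compound 3, because in this assay both stand only as limits of the assay: the limit of > 25000 nM in this assay, at which 3 of the 3 values shown sit. The compounds shown leave open at what concentration, if any, each would reach a half-maximal effect, and whether piperidin-1-yl in place of dimethylamino on an aromatic carbon changes it.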